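From benzyl to 4-bromophenyl on an aromatic nitrogen

The source may hold more compounds than are shown below. What is called first, only, known or untested is meant among the compounds shown, and "the series" means these compounds.

Measured so far in a functional assay on MDA-MB-231 cells (Homo sapiens) for inhibition, read by sulforhodamine B assay, with a stated time of 48 h; on this read-out lower numbers stand for stronger inhibition of growth and higher numbers for weaker inhibition of growth:
- compound 1 `CCn1cc(C(=O)O)c(=O)c2cnc(N3CCN(C(=O)CCSc4nnnn4-c4ccc(F)c(F)c4F)CC3)nc21`: <= 100 nM as a limit
- compound 2 `CCn1cc(C(=O)O)c(=O)c2cnc(N3CCN(C(=O)CCSc4nnnn4Cc4ccccc4)CC3)nc21`: <= 100 nM as a limit

Compound 2 reads <= 100 nM as a limit, and no number is known for it. Within the data shown here, the series so far offers only the limit of <= 100 nM in this assay, at which 2 of the 2 values shown sit, as its evidence.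

Compound 3 `CCn1cc(C(=O)O)c(=O)c2cnc(N3CCN(C(=O)CCSc4nnnn4-c4ccc(Br)cc4)CC3)nc21` has 4-bromophenyl in place of benzyl on an aromatic nitrogen. Among the measured compounds shown here, the one measured change at this place is a step that the two limits leave unreadable from compound 1 to compound 2, and it gives neither size nor direction. Compound 1, with 2,3,4-trifluorophenyl on the aromatic nitrogen, gives <= 100 nM as a limit, so compound 3 is expected to stay in the same range. For the measured compounds named here, no step of definite size is therefore expected in this assay. The estimate corresponds to an expected step that the limit leaves unreadable from compound 2 to compound 3 as a working figure. For compound 3 the estimated value is 70 nM, with an expected range from 15 nM to 300 nM.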

Compound 3, concentration for 50% growth inhibition: 220 nM
Compound 3: middle estimate off by 3.1-fold (0.50 log units), on the low side; the range from low to high includes it.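

In this assay, the group on this aromatic nitrogen gives its first readable change: 4-bromophenyl in place of benzyl is an at least 2.2-fold higher number from compound 2 to compound 3 (0.34 log units; beyond the scatter) and stands beyond the scatter. The comparison with the other aryl group points the same way, with 4-bromophenyl in place of 2,3,4-trifluorophenyl giving an at least 2.2-fold higher number from compound 1 to compound 3 (0.34 log units; beyond the scatter) as a second step beyond the scatter. An aromatic ring set directly on this nitrogen therefore does not by itself keep a compound at the limit, and compound 3 alone carries a number here, with the rest of the series resting on a limit: the limit of <= 100 nM in this assay, at which 2 of the 3 values shown sit.

From the compounds shown here alone, the step between compound 1 and compound 2 cannot be read, so the true size of both new steps stays open. Also open, going by these compounds, is how a plain phenyl or a 4-chlorophenyl group on this nitrogen would read against compound 3.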